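Cyclopentyl Amide Replaces Aryl Amide in a Pyrrolidine Series

The source may hold more compounds than are shown below. What is called first, only, known or untested is meant among the compounds shown, and "the series" means these compounds.

Compound 1 `CN1C[C@H](C(=O)Nc2ccc(C#N)cc2)[C@@H](c2ccc(/C=C/C(=O)Nc3ccccc3N)cc2)C1`: 1 mL/min/kg
Compound 2 `CC(C)c1ccc(NC(=O)[C@H]2CN(C)C[C@@H]2c2ccc(/C=C/C(=O)Nc3ccccc3N)cc2)cc1`: 10 mL/min/kg
Compound 3 `CN1C[C@H](C(=O)NC2CC2)[C@@H](c2ccc(/C=C/C(=O)Nc3ccccc3N)cc2)C1`: 10 mL/min/kg

In an in vitro ADME assay on microsomes from liver (Homo sapiens) for pharmacokinetics, read by LC-MS, with a stated time of 10 min, tested at 1 uM (a higher number here means faster removal of the compound, a lower number slower removal), compound 2 stands level with compound 3 at the digits shown, the two together the highest of the three numbers, while compound 1 lies further off (a 10-fold higher number from compound 1 to compound 2 (1.00 log units; beyond the scatter)). Compound 4 `CN1C[C@H](C(=O)NC2CCCC2)[C@@H](c2ccc(/C=C/C(=O)Nc3ccccc3N)cc2)C1` differs from compound 2 by cyclopentyl in place of 4-isopropylphenyl on an amide-type nitrogen. Going by the values given here, the only measured step that bears on this change is the one in which cyclopropyl took the place of the same aryl group, no change at the digits printed from compound 2 to compound 3 (within the scatter), and it stayed within the scatter. Given that no change at the digits printed from compound 2 to compound 3 (within the scatter) shows no movement beyond the scatter, a step of about no change at the digits printed from compound 2 to compound 4 (within the scatter) is expected, with no direction beyond the scatter. Compound 4 is therefore estimated at 10 mL/min/kg, within 5 mL/min/kg to 20 mL/min/kg.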

Compound 4, clearance: 9 mL/min/kg
The estimate for compound 4 lay 1.1-fold (0.05 log units) above the measured number, within the range that was stated.
By their numbers in this assay, from the lowest: compound 1; then compounds 4, 2 and 3 (each within the scatter of the next).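

In this assay, cyclopentyl on the amide-type nitrogen sits within the scatter of both neighbours, with a 1.1-fold lower number from compound 2 to compound 4 (0.05 log units; within the scatter) and a 1.1-fold lower number from compound 3 to compound 4 (0.05 log units; within the scatter), so a larger non-aromatic ring than cyclopropyl reads the same as 4-isopropylphenyl here. Compound 1 alone stands apart, with a 9.0-fold higher number from compound 1 to compound 4 (0.95 log units; beyond the scatter), and this gap now holds against three different amide groups. Nothing measured here accounts for this pattern. The compounds shown leave open whether an open chain such as n-butyl on the same nitrogen would match compound 4, and whether an amine on the cyclopentyl ring would move the number towards that of compound 1.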